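Aroylhydrazone series: phenyl substitution and PC-3 inhibition

A few compounds are considered here, and "the series" means these few. Any claim that something is new, unique, unknown or untested is made for them only; others in the source may bear on it.

Measured compounds:
- compound 1 `Cc1c(C(=O)N/N=C\c2ccccc2C(F)(F)F)oc2cccc(O)c12`: 26200 nM
- compound 2 `Cc1c(C(=O)N/N=C\c2c(O)cccc2F)oc2cccc(O)c12`: 8050 nM
- compound 3 `Cc1c(C(=O)N/N=C\c2ccc(O)cc2)oc2cccc(O)c12`: 21700 nM

All three share the same core and differ only in the aryl group on the carbon with a double bond to nitrogen. In a functional assay on PC-3 cells (Homo sapiens) for inhibition (a lower number here means a stronger inhibitor, a higher number a weaker inhibitor), compound 2 gives the lowest number of the three, with compound 3 nearest and compound 1 furthest away. Within the data shown here, the single one-place step available, a 2.7-fold higher number from compound 2 to compound 3 (0.43 log units; beyond the scatter), shows that replacing the 2-fluoro-6-hydroxyphenyl of compound 2 by 4-hydroxyphenyl costs potency modestly. Among the measured compounds shown here, compound 1, with 2-trifluoromethylphenyl, gives a higher number still, though no single step links it to compound 2.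

Compound 4 `Cc1c(C(=O)N/N=C\c2cc(O)ccc2O)oc2cccc(O)c12` is not yet measured. The change from compound 2 is 2,5-dihydroxyphenyl in place of 2-fluoro-6-hydroxyphenyl on a carbon with a double bond to nitrogen. For the measured compounds named here, the entering ring keeps a hydroxyl group and adds a second, while the fluorine is gone; the measured step from compound 2 to compound 3 is the only guide and is modest. A modest weakening is expected, a 1.4-fold higher number from compound 2 to compound 4 (0.14 log units; within the scatter), so compound 4 is estimated at 11000 nM in this assay, range 4000 nM to 30000 nM.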

Compound 4, half-maximal inhibitory concentration: 95500 nM
Beside the measured number, compound 4's estimate is 8.7-fold (0.94 log units) below it, outside the stated range (above it).
By their numbers in this assay, from the lowest: compound 2; then compounds 3 and 1 (each within the scatter of the next); then compound 4.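

In this assay, the aryl group on the carbon with a double bond to nitrogen can move the number much further than the earlier step suggested: 2,5-dihydroxyphenyl in place of 2-fluoro-6-hydroxyphenyl gives a 12-fold higher number from compound 2 to compound 4 (1.07 log units; beyond the scatter). Keeping a hydroxyl group on the ring is therefore not enough to hold the number down, and 2,5-dihydroxyphenyl in place of 4-hydroxyphenyl also gives a 4.4-fold higher number from compound 3 to compound 4 (0.64 log units; beyond the scatter). No measurement available here accounts for this loss.

The compounds shown do not separate the loss of fluorine from the gain of a second hydroxyl group, as the two change together in the step from compound 2. From the compounds shown here alone, how a methoxy group or an amine on this ring would compare also remains open.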